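Replacing iodo with trifluoromethyl on a weakly cytotoxic hydrazone

The source may hold more compounds than are shown below. What is called first, only, known or untested is meant among the compounds shown, and "the series" means these compounds.

Measured compounds:
compound 1, `CC(C)(C)c1ccc(C(=O)N/N=C/c2cc(I)c(O)c(I)c2)cc1`, 45900 nM
compound 2, `O=C(N/N=C/c1cc(I)c(O)c(I)c1)c1ccc(I)cc1`, > 50000 nM

Both compounds share one core and differ only in the group on the second aromatic ring. In a functional assay on HepG2 cells (Homo sapiens) for cytotoxicity, with a stated time of 24 h (on this read-out higher numbers stand for weaker inhibition and lower numbers for stronger inhibition), compound 1 gives 45900 nM. Compound 2 reaches only the limit of the assay, > 50000 nM, so no number is known for it; it sits at the limit of > 50000 nM in this assay, at which 1 of the 2 values shown sits. The change was iodo in place of tert-butyl on an aromatic carbon, and the step of an at least 1.0-fold higher number from compound 1 to compound 2 (0.03 log units; that floor lies within the scatter) stays within the usual scatter, so the two compounds cannot be told apart on this read-out.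

Compound 3, `O=C(N/N=C/c1cc(I)c(O)c(I)c1)c1ccc(C(F)(F)F)cc1`, has not yet been measured. It differs from compound 2 by trifluoromethyl in place of iodo on an aromatic carbon, placed para to a large group. Among the measured compounds shown here, the only measured step, an at least 1.0-fold higher number from compound 1 to compound 2 (0.03 log units; that floor lies within the scatter), concerned the same position and showed no change beyond the scatter, and nothing measured speaks for a trifluoromethyl group behaving otherwise. Compound 3 is therefore expected to stay near the limit, an estimated step of a number no higher from compound 2 to compound 3 (the limit leaves the size open), with a real chance that only a limit is reported again. The estimate for compound 3 is 50000 nM, ranging from 25000 nM to 100000 nM.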

Compound 3, half-maximal inhibitory concentration: 57400 nM
Beside the measured number, compound 3's estimate is 1.1-fold (0.06 log units) below it; measured number inside the range.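

Compound 3 gives a real number for this position in this assay, which compound 2 did not, so a second group on this aromatic carbon can now be compared directly with tert-butyl. That comparison is a 1.3-fold higher number from compound 1 to compound 3 (0.10 log units; within the scatter), which means that trifluoromethyl and tert-butyl cannot be told apart on this read-out, and both compounds remain only weakly cytotoxic to these cells. The step between iodo and trifluoromethyl cannot be read, since the value for compound 2 is a limit and not a number: the limit of > 50000 nM in this assay, at which 1 of the 3 values shown sits.

The compounds shown leave open whether any group at this position can move the number beyond the scatter, as an amine or a carboxylic acid placed on the same carbon might or might not do. They also leave open how much the iodo groups of the shared core contribute to this weak effect, as all three compounds carry them unchanged and a comparison with a chlorine or a hydrogen in their place is absent here.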